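The source may report more compounds than this note shows. Statements on the series, on what has been measured and on what is new or still open speak of the compounds shown alone.

In a physicochemical assay for solubility, read by HPLC, in phosphate buffer, measured as kinetic solubility, with a stated time of 1 h, at pH 7.4, tested at 250 uM (a lower number here means a less soluble compound, a higher number a more soluble compound), compound 1 `CC(C)N1CCC(c2ccc3c(c2)oc(=O)n3C(=O)NCCCCc2ccccc2)CC1` gives 50000 nM. Compound 2 `CCN1CCN(c2ccc3c(c2)oc(=O)n3C(=O)NCCCCc2ccccc2)CC1` has only a limit of the assay, < 1000 nM, and stands at the limit of < 1000 nM in this assay, at which 1 of the 2 values shown sits. Compound 3 `CCN1CCC(c2ccc3c(c2)oc(=O)n3C(=O)NCCCCc2ccccc2)CC1` differs from compound 2 by 1-ethylpiperidin-4-yl in place of 4-ethylpiperazin-1-yl on an aromatic carbon, with 1-ethylpiperidin-4-yl in place of 4-ethylpiperazin-1-yl on an aromatic carbon. Among the compounds with values here, the one measured step that bears on this is an at least 50-fold lower number from compound 1 to compound 2 (1.69 log units; beyond the scatter), large and beyond the scatter, where 4-ethylpiperazin-1-yl replaced 1-isopropylpiperidin-4-yl. Read in reverse, that step points to a large expected rise in this assay, beyond the scatter, and the estimated step is an at least 35-fold higher number from compound 2 to compound 3 (1.54 log units; beyond the scatter). For compound 3 the expected solubility is 35000 nM, with an estimated range of 10000 nM to 100000 nM.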

Compound 3, solubility: 198000 nM
Beside the measured number, compound 3's estimate is 5.7-fold (0.75 log units) below it, outside the stated range (above it).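

With the ethyl group held constant, the ring change alone in this assay gives an at least 190-fold higher number from compound 2 to compound 3 (2.29 log units; beyond the scatter) and so separates this change from the one on the ring nitrogen. Going from isopropyl to ethyl on the piperidine nitrogen gives a 4.0-fold higher number from compound 1 to compound 3 (0.60 log units; beyond the scatter) and is modest, so most of the earlier large step lies with the ring change. Compound 2 is a limit, so the steps that involve it are bounds only: the limit of < 1000 nM in this assay, at which 1 of the 3 values shown sits.

Still open, from the compounds shown here alone, is how a morpholin-4-yl group or a piperidin-4-yl group with a free nitrogen would read at this aromatic carbon in this assay as a comparison with these rings.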